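Bromo for phenoxy at the aromatic carbon of compound 3

A few compounds are considered here, and "the series" means these few. Any claim that something is new, unique, unknown or untested is made for them only; others in the source may bear on it.

Working notes on the series. In a functional assay on MCF7 cells (Homo sapiens) for cytotoxicity, read by MTT assay, with a stated time of 72 h (on this read-out lower numbers stand for an effect already at smaller amounts and higher numbers for an effect only at larger amounts of compound), compound 1 `O=C1/C(=C\c2cc3ccccc3nc2Cl)c2ccccc2N1c1c(Cl)cccc1Cl` reaches only the limit > 100 ug/mL, which is a limit of the assay and not a number. Compound 2 `O=C1/C(=C\c2ccc(O)cc2)c2ccccc2N1c1c(Cl)cccc1Cl` gives 20 ug/mL in this assay. Compound 3 `O=C1/C(=C\c2cccc(Oc3ccccc3)c2)c2ccccc2N1c1c(Cl)cccc1Cl` gives 100 ug/mL in this assay, the higher of the two numbers actually recorded; the number of compound 2 lies lower, beyond the usual scatter. Within the data shown here, the one value at the limit is described by the limit of > 100 ug/mL in this assay, at which 1 of the 3 values shown sits.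

Compound 4 `O=C1/C(=C\c2cccc(Br)c2)c2ccccc2N1c1c(Cl)cccc1Cl` is not yet measured. Relative to compound 3 the change is bromo in place of phenoxy on an aromatic carbon. Among the measured compounds shown here, no step between two measured compounds carries this exchange, so its size is open. The expectation is a step from compound 3 to compound 4 of a 2.0-fold lower number from compound 3 to compound 4 (0.30 log units; within the scatter) in this assay, toward a lower number but of modest size. For compound 4 a value of 50 ug/mL is estimated in this assay, within 15 ug/mL to 100 ug/mL, with a fair chance that only a limit is reported.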

Compound 4, concentration for half-maximal effect: 5 ug/mL
Compound 4: middle estimate off by 10-fold (1.00 log units), on the high side, outside the stated range (below it).
By their numbers in this assay, from the lowest: compound 4; then compound 2; then compound 3.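

In this assay, bromo in place of phenoxy on an aromatic carbon, meta to a large group, gives a 20-fold lower number from compound 3 to compound 4 (1.30 log units; beyond the scatter): the first step read at this position, and it shows that the number responds strongly to the group placed there. The exchange of 3-bromophenyl for 4-hydroxyphenyl gives a 4.0-fold lower number from compound 2 to compound 4 (0.60 log units; beyond the scatter), which leaves compound 4 with the lowest of the recorded numbers. No measured property in hand accounts for either step.

From the compounds shown here alone, whether the gain belongs to bromo itself or to the loss of the phenoxy ring stays open; a methyl, an amine or a carboxylic acid on the same aromatic carbon would bear on that. The step from compound 2 also changes both the group and its place on the ring, so the contribution of each remains unseparated.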